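This account rests on a few compounds, and the source may have more. Where it says the series, first, only, none or still open, it means among the compounds named here.

Compound 1 `COc1nccnc1C1CN2CCC1CC2` and compound 2 `CCCCCCOc1nccnc1C1CN2CCC1CC2` share one core and differ only in the chain on the oxygen. In a functional assay on A9L-m1 cells with A9 (Mus musculus) as the target (a lower number here means a smaller maximal response, a higher number a larger maximal response), compound 1 gives 1%, while compound 2 gives 40%, the higher of the two numbers; the step of a number 39 percentage points higher from compound 1 to compound 2 (beyond the scatter) came with pentyl in place of hydrogen on a saturated chain carbon bound to an oxygen on an aromatic ring. Compound 3 `CCCCCCCOc1nccnc1C1CN2CCC1CC2` takes one more step of the same kind: methyl in place of hydrogen on a saturated chain carbon, six bonds along the chain from an oxygen on an aromatic ring. Going by the values given here, because the single step of a number 39 percentage points higher from compound 1 to compound 2 (beyond the scatter) was large, a further, smaller rise in this assay is expected, so that compound 3 is estimated at 50%, within 25% to 80%, a step of a number 10 percentage points higher from compound 2 to compound 3 (within the scatter).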

Compound 3, largest response reached (reported as maximum), in percent of the reference or control that the assay uses: 35%
Compound 3: the middle estimate sits 15 percentage points above what was measured; low and high end bracket the measured number.
By their numbers in this assay, from the lowest: compound 1; then compounds 3 and 2 (each within the scatter of the next).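

Adding methyl six bonds along the chain from the oxygen on the aromatic ring gives a number 5 percentage points lower from compound 2 to compound 3 (within the scatter) in this assay, so compounds 2 and 3 cannot be told apart. The longer chain keeps the large gain over the short chain, with a number 34 percentage points higher from compound 1 to compound 3 (beyond the scatter) as the step. No measurement bears on why the response behaves this way.

Chains of intermediate length, such as ethyl or butyl, could show where the gain arises between compound 1 and compound 2. An octyl or still longer chain could show whether the response holds.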